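This account rests on a few compounds, and the source may have more. Where it says the series, first, only, none or still open, it means among the compounds named here.

Of the compounds shown here, three sharing one core have been measured in an ADME assay on L02 cells (Homo sapiens) for cytotoxicity, read by MTT assay, with a stated time of 24 h; on this read-out lower numbers stand for stronger inhibition and higher numbers for weaker inhibition. Compound 1 `O=C1/C(=C/c2ccccc2F)CN(S(=O)(=O)c2ccc(O[N+](=O)[O-])cc2)C/C1=C\c1ccccc1F` gives 15500 nM. Among the measured compounds shown here, compound 2 `O=C1/C(=C/c2ccccc2F)CN(S(=O)(=O)c2ccc(C(F)(F)F)cc2)C/C1=C\c1ccccc1F` gives 16200 nM; the step of a 1.0-fold higher number from compound 1 to compound 2 (0.02 log units; within the scatter) is the only single change measured so far. Compound 3 `O=C1/C(=C/c2cccc(F)c2)CN(S(=O)(=O)c2ccccc2)C/C1=C\c1cccc(F)c1` gives 16200 nM, which stands level with compound 2 at the digits shown and, together with it, at the top of the three numbers, with compound 1 the furthest of them and still within the scatter; no ordering among the three can be read from this.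

Compound 4 `O=C1/C(=C/c2cccc(F)c2)CN(S(=O)(=O)c2ccc(O[N+](=O)[O-])cc2)C/C1=C\c1cccc(F)c1` is not yet measured. It differs from compound 3 by nitrooxy in place of hydrogen on an aromatic carbon. For the measured compounds named here, the one measured step that touches this group, a 1.0-fold higher number from compound 1 to compound 2 (0.02 log units; within the scatter), lies within the scatter, and the three numbers together spread less than the scatter, so in this assay compound 4 is expected to show no step beyond the scatter, a 1.0-fold lower number from compound 3 to compound 4 (0.01 log units; within the scatter). The estimate for compound 4 is 15800 nM, with a range from 8000 nM to 32000 nM.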

Compound 4, half-maximal inhibitory concentration: 10700 nM
The estimate for compound 4 lay 1.5-fold (0.17 log units) above the measured number, within the range that was stated.
By their numbers in this assay, from the lowest: compounds 4, 1, 2 and 3 (each within the scatter of the next).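

In this assay, among the compounds shown here, the change from phenyl to 4-(nitrooxy)phenyl gives a 1.5-fold lower number from compound 3 to compound 4 (0.18 log units; within the scatter), the first comparison of nitrooxy with hydrogen at this place on the aromatic ring. The earlier step, a 1.0-fold higher number from compound 1 to compound 2 (0.02 log units; within the scatter), compared only nitrooxy with trifluoromethyl; with both steps inside the scatter, neither exchange separates the compounds at this place in this assay. Nothing shown here gives a reason for the direction or size of the new step.

The compounds shown leave open how an amine, a carboxylic acid or a longer chain would read at this place on the aromatic ring. On these data alone, it also remains open whether nitrooxy in place of hydrogen would give a similar step with the fluorine placement of compound 1.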